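The source may report more compounds than this note shows. Statements on the series, on what has been measured and on what is new or still open speak of the compounds shown alone.

Working notes on the series. In a functional assay for inhibition, with Sus scrofa as the target (a higher number here means a weaker inhibitor, a lower number a stronger inhibitor), compound 1 `CC1(C)C=C(n2ccccc2=O)c2cc(C#N)ccc2O1` gives 50 nM. Compound 2 `CC1(C)Oc2ccc(C#N)cc2[C@@H](N2CCCC2=O)[C@]1(C)O` gives 4000 nM, the higher of the two numbers, and its gap to compound 1 lies beyond the scatter. Compound 3 `CC1=C(N2CCCC2=O)c2cc(C#N)ccc2OC1(C)C` is reported only as a limit, > 100000 nM. Compound 4 `CC1(C)Oc2ccc(C#N)cc2[C@@H](OC2=CC(=O)CC2)[C@]1(C)O` has not yet been measured. It keeps the core of compound 2 and differs in one group, on a saturated ring carbon, next to the ring atom that bears a hydroxy group: a group of 7 heavy atoms (5 carbon, 2 oxygen; one five-membered non-aromatic ring of carbon only) in place of a group of 6 heavy atoms (4 carbon, 1 nitrogen, 1 oxygen; one five-membered non-aromatic ring with 1 hetero atom), on a saturated ring carbon. Among the measured compounds shown here, no measured pair isolates this change, so the direction is not firmly set. The expectation therefore starts from compound 2 at 4000 nM, with no shift beyond the scatter in this assay. The expected change is a 1.3-fold lower number from compound 2 to compound 4 (0.12 log units; within the scatter), an estimated step of small size. The estimated value for compound 4 is 3000 nM, with an expected range from 400 nM to 25000 nM.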

Compound 4, half-maximal inhibitory concentration: 20 nM
The estimate for compound 4 lay 150-fold (2.18 log units) above the measured number; the whole stated range lies above it.
By their numbers in this assay, from the lowest: compound 4; then compound 1; then compound 2. At a limit, above all of these: compound 3.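

At this saturated ring carbon, next to the ring atom that bears a hydroxy group, the substituent strongly affects the read-out: in this assay, exchanging 2-oxopyrrolidin-1-yl for the group with one five-membered non-aromatic ring of carbon only gives a 200-fold lower number from compound 2 to compound 4 (2.30 log units; beyond the scatter). The core of compound 2 therefore does not fix the number at its level, and a lactam-type nitrogen group is not required at this position in this pair. Nothing given here bears on the cause of this step.

This single change replaces the ring hetero atom and adds a double bond and a hydrogen-bond acceptor together, so the contribution of each remains unresolved. Also open, going by these compounds, is how a simple amine, a carboxylic acid or a longer alkyl chain would read at this ring carbon.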